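A few compounds are considered here, and "the series" means these few. Any claim that something is new, unique, unknown or untested is made for them only; others in the source may bear on it.

Of the compounds shown here, two have so far been measured in a functional assay on MKN-45 cells (Homo sapiens) for cytotoxicity, read by MTT assay, with a stated time of 72 h; on this read-out higher numbers stand for weaker inhibition and lower numbers for stronger inhibition. Compound 1 `COc1cc2c(Oc3ccc(NC(=O)c4nnn(-c5ccccc5)c4C)cc3F)ccnc2cc1OCCCN1CCCCC1` gives 80 nM in this assay. Compound 2 `COc1cc2c(Oc3ccc(NC(=O)c4nnn(-c5ccccc5C)c4C)cc3F)ccnc2cc1OCCCN1CCC(C)CC1` gives 120 nM in this assay. On the numbers shown, compound 2 carries the larger of the two values, but its gap to compound 1 lies within the usual scatter, so the two results cannot be told apart, and no step between them has been worked out; only what each value shows can be stated.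

Compound 3 `COc1cc2c(Oc3ccc(NC(=O)c4nnn(-c5ccccc5)c4C)cc3F)ccnc2cc1OCCCN1CCC(C)CC1` has not yet been measured. It differs from compound 2 in one place: hydrogen in place of methyl on an aromatic carbon. Among the measured compounds shown here, no pair of measured compounds shows this same change, so there is no measured step to lean on. With nothing pointing either way, the step from compound 2 to compound 3 is expected to stay within the scatter, as a 1.2-fold lower number from compound 2 to compound 3 (0.08 log units; within the scatter). Compound 3 is therefore estimated at 100 nM in this assay, with a plausible range from 45 nM to 220 nM.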

Compound 3, half-maximal inhibitory concentration: 90 nM
The estimate for compound 3 lay 1.1-fold (0.05 log units) above the measured number; the range from low to high includes it.
By their numbers in this assay, from the lowest: compounds 1, 3 and 2 (each within the scatter of the next).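

In this assay, hydrogen in place of methyl on an aromatic carbon, ortho to a large group, turns 2-methylphenyl into phenyl and gives a 1.3-fold lower number from compound 2 to compound 3 (0.12 log units; within the scatter), so the measured values do not separate these two forms at this position. Compound 3 also supplies a second single change, methyl in place of hydrogen on a saturated ring carbon, which gives a 1.1-fold higher number from compound 1 to compound 3 (0.05 log units; within the scatter), so neither of the two single changes read here takes the number beyond the scatter. No measurement is at hand that would explain either result.

On these data alone, both steps concern only methyl against hydrogen, so it remains open whether a methoxy group or a chlorine atom on that aromatic carbon would give a number that can be told apart from those of compound 2 and compound 3. As far as these compounds go, it is equally open whether an ethyl group or a longer chain on the saturated ring carbon would stay within the scatter of compound 1 and compound 3.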